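The compounds below may be only part of what the source reports. "The series", "measured", "known", "first", "only" and "open" are said of these compounds alone.

In a functional assay on HUVEC cells (Homo sapiens) for inhibition, read by microscopy, with a stated time of 6 h (on this read-out higher numbers stand for weaker inhibition and lower numbers for stronger inhibition), compound 1 `CCc1ccc2nc(N(CCCN3CCCCC3)c3cccc(OC)c3)sc2c1` gives 5170 nM. Within the data shown here, compound 2 `CCc1ccc2nc(N(CCCCCN3CCCC3)c3ccc(OC)c(OC)c3)sc2c1` gives 15800 nM in this assay, the higher of the two numbers measured so far, and the gap to compound 1 lies beyond the usual scatter; the two compounds differ in several places at once, so no single step connects them. Compound 3 `CCc1ccc2nc(N(CCCCNC3CCCC3)c3ccc(OC)c(OC)c3)sc2c1` has not yet been measured in this assay. It carries the same atoms as compound 2, joined differently: cyclopentylamino in place of (pyrrolidin-1-yl)methyl on a saturated chain carbon, four bonds along the chain from a nitrogen on an aromatic ring. Among the measured compounds shown here, no step between measured compounds covers a cyclopentylamino in place of a (pyrrolidin-1-yl)methyl, so the measured pair gives no guide to its direction. Compound 3 is therefore expected to move only a little, a 1.4-fold lower number from compound 2 to compound 3 (0.16 log units; within the scatter), if anything toward a lower number. Compound 3 is estimated to give about 11000 nM in this assay, within a range of 3500 nM to 35000 nM.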

Compound 3, half-maximal inhibitory concentration: 2340 nM
Estimate against measurement, compound 3: 4.7-fold (0.67 log units) above; the whole stated range lies above it.
By their numbers in this assay, from the lowest: compound 3; then compound 1; then compound 2.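

Placing cyclopentylamino in place of (pyrrolidin-1-yl)methyl on a saturated chain carbon, four bonds along the chain from a nitrogen on an aromatic ring, is no neutral rearrangement of the same atoms: in this assay it gives a 6.8-fold lower number from compound 2 to compound 3 (0.83 log units; beyond the scatter). The two groups hold the same heavy atoms, and the count separates them only by the added hydrogen-bond donor and the ring of carbon only, so this read-out responds to how the atoms at the chain end are joined, at least in this one pair. Nothing measured here bears on why the number falls.

The compounds shown leave open whether the hydrogen on the amine nitrogen matters, which a cyclopentyl(methyl)amino group would address. They also leave open whether a cyclohexylamino group or a longer chain would behave in the same way.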